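Cytotoxicity of pyrazoline amides with a piperazine tail

The source may report more compounds than this note shows. Statements on the series, on what has been measured and on what is new or still open speak of the compounds shown alone.

Measured compounds:
Compound 1 `CC1=NN(S(=O)(=O)c2ccc([N+](=O)[O-])cc2)C(c2cc(Cl)ccc2O)C1`: "not active" (no number reported)
Compound 2 `CC(=O)Oc1ccccc1C1CC(C)=NN1C(=O)CN1CCCCC1`: 19000 nM
Compound 3 `CCC(=O)N1N=C(c2cc3ccccc3oc2=O)CC1c1ccccc1`: 9610 nM

Of the compounds shown here, three have been tested in a functional assay on HepG2 cells (Homo sapiens) for cytotoxicity, read by MTT assay, with a stated time of 48 h; on this read-out higher numbers stand for weaker inhibition and lower numbers for stronger inhibition. For compound 1 the result is reported as "not active" (no number reported), with no number given. Compound 2 gives 19000 nM, and compound 3 gives 9610 nM. Among the two compounds with a number, compound 3 has the lowest value, but its gap to compound 2 lies within the scatter of repeated measurements, so the two cannot be ordered on these data.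

Compound 4 `CN1CCN(CC(=O)N2N=C(c3cc4ccccc4oc3=O)CC2c2ccccc2)CC1` is not yet measured. It differs from compound 3 in one place: 4-methylpiperazin-1-yl in place of methyl on a saturated chain carbon bound to a carbonyl carbon. Put another way, the propanoyl group of compound 3 becomes a ((4-methylpiperazin-1-yl)methyl)carbonyl group in compound 4.

Going by the values given here, no pair of measured compounds differs in a single place, so the weight of this change cannot be read from a measured step. Compound 2, which also carries a ring amine on the chain carbon bound to the carbonyl carbon, sits within the scatter of compound 3, and this is the only hint available. In this assay compound 4 is therefore expected to land close to compound 3, with a step of a 1.2-fold higher number from compound 3 to compound 4 (0.10 log units; within the scatter) that is not expected to exceed the scatter in either direction. The estimate for compound 4 is 12000 nM, with a range from 4000 nM to 40000 nM.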

Compound 4, half-maximal inhibitory concentration: 33100 nM
The estimate for compound 4 lay 2.8-fold (0.44 log units) below the measured number, within the range that was stated.
By their numbers in this assay, from the lowest: compounds 3, 2 and 4 (each within the scatter of the next, the first and the last beyond it).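

In this assay, going by these compounds alone, replacing methyl with 4-methylpiperazin-1-yl on a saturated chain carbon bound to a carbonyl carbon gives a 3.4-fold higher number from compound 3 to compound 4 (0.54 log units; beyond the scatter), the first measured single-place step in this set. It shows that, on this core, the group carried at this position can shift the read-out beyond the scatter, and that this exchange of 1 heavy atom for 7 goes with weaker inhibition, not stronger. The earlier compounds could not show this, as no two of them differed in only one place, and nothing at hand explains the direction or size of the step.

As far as these compounds go, whether the shift follows from the piperazine ring itself, from the added amine or simply from a larger group remains open, and a morpholin-4-yl group, a dimethylamino group or a plain longer chain such as butanoyl at the same position would be needed to separate these readings. From the compounds shown here alone, as this is a single pair, it also remains open whether the same exchange would give a similar step on another core.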